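A new ring on compound 1: what to expect

A few compounds are considered here, and "the series" means these few. Any claim that something is new, unique, unknown or untested is made for them only; others in the source may bear on it.

- compound 1 `Cc1ccc(S(=O)(=O)c2nc3ccccc3nc2N2CCCC2)cc1`: > 50000 nM
- compound 2 `COc1ccc(S(=O)(=O)c2nc3ccccc3nc2N2CCCC2)cc1`: > 50000 nM
- compound 3 `O=S(=O)(c1ccc(F)cc1)c1nc2ccccc2nc1N1CCCC1`: 31100 nM

In a functional assay on A549 cells (Homo sapiens) for cytotoxicity, read by MTT assay, with a stated time of 72 h (a higher number here means a weaker inhibitor, a lower number a stronger inhibitor), compound 1 gives > 50000 nM, which is a limit and not a number. Compound 2 gives > 50000 nM, which is also a limit. Compound 3 gives a true number, 31100 nM.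

Compound 4 `Cc1ccc(S(=O)(=O)c2nc3ccccc3nc2N2CCCC(O)C2)cc1` differs from compound 1 elsewhere: 3-hydroxypiperidin-1-yl in place of pyrrolidin-1-yl on an aromatic carbon. The measured steps only exchange methyl, methoxy and fluoro, so none tests this swap directly. Of those steps, a step that the two limits leave unreadable from compound 1 to compound 2 cannot be sized, while an at least 1.6-fold lower number from compound 1 to compound 3 (0.20 log units; that floor lies within the scatter) and an at least 1.6-fold lower number from compound 2 to compound 3 (0.20 log units; that floor lies within the scatter) give no firm guide. No step beyond the scatter is therefore expected in this assay. The estimated change is an at least 1.1-fold lower number from compound 1 to compound 4 (0.04 log units; that floor lies within the scatter). Compound 4 is expected at 45000 nM, with an estimated range of 20000 nM to 100000 nM.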

Compound 4, half-maximal inhibitory concentration: 1350 nM
Compound 4: middle estimate off by 33-fold (1.52 log units), on the high side; measured number outside the range, below it.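

In this assay, among these compounds, the swap of pyrrolidin-1-yl for 3-hydroxypiperidin-1-yl on this aromatic carbon gives an at least 37-fold lower number from compound 1 to compound 4 (1.56 log units; beyond the scatter) and is the first readable step beyond the scatter. The exchanges of methyl, methoxy and fluoro did not show that the read-out could shift this strongly. The true step may be larger still, because compound 1 stands at a limit and not a number: the limit of > 50000 nM in this assay, at which 2 of the 4 values shown sit.

Whether the larger ring or the hydroxy group accounts for the step stays open. Piperidin-1-yl or 3-hydroxypyrrolidin-1-yl at this position would separate the two.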